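The source may report more compounds than this note shows. Statements on the series, on what has been measured and on what is new or still open speak of the compounds shown alone.

In a functional assay on Jurkat cells (Homo sapiens) for cytotoxicity, with a stated time of 48 h (on this read-out higher numbers stand for weaker inhibition and lower numbers for stronger inhibition), compound 1 (`CCOC(=O)CC1C(C(=O)OCC)=C(N)Oc2ccccc21`) gives 91400 nM. Two relatives carry a phenyl at different places on the shared core: compound 2 (`CCOC(=O)CC1C(C(=O)OCC)=C(N)Oc2cccc(-c3ccccc3)c21`) gives 44300 nM, and compound 3 (`CCOC(=O)CC1C(C(=O)OCC)=C(N)Oc2cc(-c3ccccc3)ccc21`) gives 51600 nM. The number for compound 1 is the highest of the three, but only narrowly: a 2.1-fold lower number from compound 1 to compound 2 (0.31 log units; beyond the scatter), while a 1.8-fold lower number from compound 1 to compound 3 (0.25 log units; within the scatter).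

Compound 4 (`CCOC(=O)CC1C(C(=O)OCC)=C(N)Oc2ccc(-c3cc(O)cc(O)c3)cc21`) has not yet been measured. It differs from compound 1 by a single change: 3,5-dihydroxyphenyl in place of hydrogen on an aromatic carbon. The 3,5-dihydroxyphenyl sits on an aromatic carbon, at a place that carries the phenyl in neither compound 2 nor compound 3. Those two phenyl steps are the closest evidence, and both are small. Among the measured compounds shown here, no measured compound carries this substituted ring, so the forecast is loose. A small step toward a lower number is expected, and its estimated size is a 2.3-fold lower number from compound 1 to compound 4 (0.36 log units; beyond the scatter). For compound 4 the estimated value is 40000 nM, with an expected range from 12000 nM to 100000 nM.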

Compound 4, half-maximal inhibitory concentration: 18300 nM
Beside the measured number, compound 4's estimate is 2.2-fold (0.34 log units) above it; measured number inside the range.
By their numbers in this assay, from the lowest: compound 4; then compounds 2, 3 and 1 (each within the scatter of the next, the first and the last beyond it).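

The 3,5-dihydroxyphenyl on this aromatic carbon produces a 5.0-fold lower number from compound 1 to compound 4 (0.70 log units; beyond the scatter). That step is larger than either phenyl step, which were a 2.1-fold lower number from compound 1 to compound 2 (0.31 log units; beyond the scatter) and a 1.8-fold lower number from compound 1 to compound 3 (0.25 log units; within the scatter), so a ring carrying hydroxyl groups at this third place on the shared core can lower the number further than those earlier changes did. No measurement shown gives a reason for this larger step.

The compounds shown do not separate the effect of the position from that of the hydroxyl groups, since none has an unsubstituted phenyl on this same carbon, and compound 4 differs from compounds 2 and 3 in both respects. A phenyl bearing methoxy groups or amines in place of the hydroxyl groups, placed on this carbon, would be needed to show whether the hydroxyl groups themselves matter.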